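Naphthalen-1-yl in Place of 2-Chlorophenyl on the Shared Core

The compounds below may be only part of what the source reports. "The series", "measured", "known", "first", "only" and "open" are said of these compounds alone.

Compound 3 `N#CC1=C(N)OC(c2c[nH]c3ccccc23)=C(C#N)C1c1ccccc1Cl` reaches only the limit of the assay, giving > 1000 ug/mL in a functional assay; on this read-out higher numbers stand for weaker inhibition and lower numbers for stronger inhibition. Compound 2 `Cc1ccc(C2C(C#N)=C(N)OC(c3c[nH]c4ccccc34)=C2C#N)cc1` likewise gives a limit, > 1000 ug/mL in this assay. Compound 1 `CN(C)c1ccc(C2C(C#N)=C(N)OC(c3c[nH]c4ccccc34)=C2C#N)cc1` gives 900 ug/mL in this assay, a number lying near (the limit of > 1000 ug/mL in this assay, at which 2 of the 3 values shown sit). Compound 4 `N#CC1=C(N)OC(c2c[nH]c3ccccc23)=C(C#N)C1c1cccc2ccccc12` differs from compound 3 in one place: naphthalen-1-yl in place of 2-chlorophenyl on a saturated ring carbon. The measured steps at that saturated ring carbon are an at least 1.1-fold higher number from compound 1 to compound 3 (0.04 log units; that floor lies within the scatter) and a step that the two limits leave unreadable from compound 2 to compound 3; neither shows a change beyond the scatter, and none is expected here either. Compound 4 is therefore expected to give 1000 ug/mL in this assay, between 500 ug/mL and 2000 ug/mL, most probably again only as a limit. The step of a number no higher from compound 3 to compound 4 (the limit leaves the size open) is expected to stay within the scatter.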

Compound 4, half-maximal inhibitory concentration: > 1000 ug/mL
Compound 4: only a limit was reported; the forecaster's own chance of this, stated with the estimate: 70%; the middle value lies on the limit itself.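

Naphthalen-1-yl, with its two six-membered aromatic rings of carbon only, is a further group on this saturated ring carbon that leaves the read-out at the limit in this assay: the limit of > 1000 ug/mL in this assay, at which 3 of the 4 values shown sit. Going by these compounds alone, the one readable step is an at least 1.1-fold higher number from compound 1 to compound 4 (0.04 log units; that floor lies within the scatter); the other two steps lie between limits and cannot be read. So enlarging the aromatic group here brought no measurable number. From the compounds shown here alone, whether a carboxylic acid or a morpholine on the phenyl ring at this carbon would give a number clearly away from that limit stays open.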